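Adding a Methyl to a Stable Carbamate Biaryl Ether

A few compounds are considered here, and "the series" means these few. Any claim that something is new, unique, unknown or untested is made for them only; others in the source may bear on it.

Three compounds of one series have been run in an ADME assay on microsomes from liver (Rattus norvegicus) for metabolic stability, read by LC-MS, using NADPH, with a stated time of 10 min, tested at 0.5 uM; a lower number here means that less of the compound is left, a higher number that more of the compound is left. Compound 1 `Cc1cc(-c2ccnc(C(F)F)c2)ncc1OC[C@@](C)(N)CC(C)C` gives 76% in this assay. Compound 3 `CC(=O)Nc1cc(-c2ccc(OC[C@@H](N)CC(C)C)c(F)c2)ccn1` gives 80%. Compound 2 `COC(=O)Nc1cc(-c2ccc(OC[C@@](C)(N)CC(C)C)c(C)c2)ccn1` gives 96%, the highest of the three numbers: the nearest is compound 3, whose number is lower by a step beyond the scatter, and the furthest is compound 1, whose number is lower by a step also beyond the scatter. Compound 2 thus stands alone at the top of the measured set.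

The account now turns from compound 2 to compound 4 `COC(=O)Nc1cc(-c2ccc(OC[C@@](C)(N)CC(C)C)c(C)c2C)ccn1`, which has not yet been measured in this assay. The two differ in one place: methyl in place of hydrogen on an aromatic carbon. The change is small, a methyl in place of hydrogen on an aromatic carbon, ortho to a large group and ortho to a methyl group, meta to the (2-amino-2,4-dimethylpentyl)oxy group. Among the measured compounds shown here, no measured pair in this set shows the effect of such a change, so the expectation rests on the high number of compound 2 in this assay and on the small size of the alteration. The expected step is a number 6 percentage points lower from compound 2 to compound 4 (within the scatter), a slight drop that may well fall within the scatter. Compound 4 is therefore estimated at 90%, with a range from 78% to 98%.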

Compound 4, percent of the compound remaining: 83%
Estimate against measurement, compound 4: 7 percentage points above, within the range that was stated.
By their numbers in this assay, from the lowest: compounds 1, 3 and 4 (each within the scatter of the next); then compound 2.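

In this assay, among the compounds shown here, this is the first pair in the set that differs in one place, and it shows that the position is not indifferent to substitution. A methyl in place of hydrogen on this aromatic carbon, ortho to a large group and ortho to a methyl group, and meta to the (2-amino-2,4-dimethylpentyl)oxy group, brings a number 13 percentage points lower from compound 2 to compound 4 (beyond the scatter). The step is modest, yet a change of a single carbon moves the percent of compound remaining by more than the usual scatter of repeated measurements. Nothing available bears on why the number falls at this position.

The compounds shown leave open whether this step belongs to the methyl itself or would also follow from another group on the same carbon, such as a fluorine, a chlorine or a methoxy group. They also leave open whether the same methyl would bring a similar step on a compound carrying the acetamide of compound 3 in place of the methyl carbamate of compound 4.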